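Urea series, terminal aryl group: fluoro to methyl

The compounds below may be only part of what the source reports. "The series", "measured", "known", "first", "only" and "open" are said of these compounds alone.

Two compounds of this series have numbers in a functional assay on MDA-MB-231 cells (Homo sapiens) for cytotoxicity, read by MTT assay, with a stated time of 72 h; on this read-out lower numbers stand for stronger inhibition and higher numbers for weaker inhibition. Compound 1 `CN(C)CCCNc1nc(-c2ccc(NC(=O)Nc3ccc(Cl)cc3)cc2)nc2c(Cl)c(Cl)sc12` gives 1160 nM. Compound 2 `CN(C)CCNc1nc(-c2ccc(NC(=O)Nc3ccc(F)cc3)cc2)nc2ccsc12` gives 540 nM in this assay, the lower of the two numbers; the gap to compound 1 lies beyond the scatter, though the two structures differ in more than one place and no single step can be read from them. Compound 3 `Cc1ccc(NC(=O)Nc2ccc(-c3nc(NCCN(C)C)c4sccc4n3)cc2)cc1` is not yet measured in this assay. It differs from compound 2 in one place: methyl in place of fluoro on an aromatic carbon of the terminal ring, para to a large group. Among the compounds with values here, no measured pair shows the effect of this change, so no direction is established. With a swap of one heavy atom for another and no change in donors, acceptors or charge, the step expected from compound 2 to compound 3, a 1.1-fold higher number from compound 2 to compound 3 (0.06 log units; within the scatter), is small, likely within the scatter, with no firm direction. For compound 3 the expected half-maximal inhibitory concentration in this assay is 620 nM, within 250 nM to 1600 nM.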

Compound 3, half-maximal inhibitory concentration: 2180 nM
Estimate against measurement, compound 3: 3.5-fold (0.55 log units) below; measured number outside the range, above it.
By their numbers in this assay, from the lowest: compound 2; then compounds 1 and 3 (each within the scatter of the next).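

In this assay, within the data shown here, going from 4-fluorophenyl to 4-methylphenyl gives a 4.0-fold higher number from compound 2 to compound 3 (0.61 log units; beyond the scatter), the first step that can be read at a single place. This position on the aromatic ring, para to a large group, is therefore sensitive to the exchange of one heavy atom for another, even with no change in hydrogen-bond donors, hydrogen-bond acceptors or net charge. For this pair, fluoro carries the lower number, but nothing shown gives a measured reason for the step.

Compound 1 differs from compound 2 and from compound 3 in more than one place, so its steps to them cannot be read, and the effect of its chloro group on the terminal ring stays unresolved. Going by these compounds, with only fluoro and methyl compared here on one core and one side chain, it remains open whether a methoxy group, a trifluoromethyl group or an amine at this position would fall near compound 2 or compound 3, and whether the step would persist with a longer chain on the core.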